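A few compounds are considered here, and "the series" means these few. Any claim that something is new, unique, unknown or untested is made for them only; others in the source may bear on it.

The study concerns a set of close relatives built on one shared core. Compound 1 `CC(C)c1ncc([C@@H](CCCCCCc2ccc3c(n2)NCCC3)CC(=O)O)cn1` is the starting point of this step. In an in vivo ADME assay on the whole organism (Canis lupus familiaris) for metabolic stability (a lower number here means that the compound disappears faster, a higher number that the compound lasts longer), compound 1 is recorded as "not determined" (no result reported), so no single number places it. Its neighbour, compound 2 `COc1ncc([C@@H](CCCCCCc2ccc3c(n2)NCCC3)CC(=O)O)cn1`, was measured: in this assay compound 2 gives 6.8 h. Compound 3 `O=C(O)C[C@H](CCCCCCc1ccc2c(n1)NCCC2)c1ccc2c(c1)OCC2` differs from compound 1 by one exchange: a group of 9 heavy atoms (8 carbon, 1 oxygen; one five-membered non-aromatic ring with 1 hetero atom, one six-membered aromatic ring of carbon only) in place of a group of 9 heavy atoms (7 carbon, 2 nitrogen; one six-membered aromatic ring with 2 hetero atoms), on a saturated chain carbon bound to two saturated chain carbons. Compound 2 and compound 3 also differ from each other, so the value of compound 2 serves only as a loose anchor. Within the data shown here, with no measured step showing how this exchange moves this assay, no direction can be expected with confidence; the step might fall either way, and a change no larger than the scatter is the plainest assumption. Compound 3 is therefore estimated to last about 5.5 h, with an expected range from 2 h to 14 h.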

Compound 3, half-life in the Canis lupus familiaris assay: 5.8 h
Estimate against measurement, compound 3: 1.1-fold (0.02 log units) below; low and high end bracket the measured number.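

In the Canis lupus familiaris assay, changing the group on this saturated chain carbon gives a 1.2-fold lower number from compound 2 to compound 3 (0.07 log units; within the scatter), so a six-membered aromatic ring of carbon only with a five-membered non-aromatic ring holds up here as well as the six-membered aromatic ring with 2 hetero atoms. In a physicochemical assay for lipophilicity (on this read-out lower numbers stand for lower lipophilicity and higher numbers for higher lipophilicity), compound 1 gives 1.32 and compound 3 gives 2.39, so the exchange of 2-isopropylpyrimidin-5-yl for the group of compound 3 does move this second read-out. The group in compound 3 is the more lipophilic of the two at this place: the measured partition coefficient of compound 1, 1.32, and of compound 3, 2.39, a number 1.07 log units higher (beyond the scatter)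

The values shown for the Canis lupus familiaris assay belong to compound 2 and compound 3, and those for the physicochemical assay to compound 1 and compound 3, so the two read-outs cannot yet be tied together. Also open, on these data alone, is how a plain phenyl or an amine at this place would move either number.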